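A few compounds are considered here, and "the series" means these few. Any claim that something is new, unique, unknown or untested is made for them only; others in the source may bear on it.

Compound 1 `CCOC(=O)c1csc2nc(CN3CCN(C)CC3)c(-c3ccc(Br)cc3)n12`: 93600 nM
Compound 2 `Cc1ccc(-c2c(CN3CCCCC3)nc3scc(C(=O)O)n23)cc1`: 13800 nM
Compound 3 `CC(=O)NNC(=O)c1csc2ncc(-c3ccc(C)cc3)n12`: 71800 nM

In a functional assay on HCT-116 cells (Homo sapiens) for antiproliferative activity, read by MTT assay, with a stated time of 72 h (a lower number here means a stronger inhibitor, a higher number a weaker inhibitor), compound 3 at 71800 nM lies within the usual scatter of compound 1 at 93600 nM. Its number is clearly higher, meaning weaker inhibition, than that of compound 2 at 13800 nM. Compound 4 `CCCC(=O)NNC(=O)c1csc2ncc(-c3ccc(C)cc3)n12` keeps the core of compound 3 and changes one small part: ethyl in place of hydrogen on a saturated chain carbon bound to a carbonyl carbon. This places ethyl in place of hydrogen on a saturated chain carbon bound to a carbonyl carbon, turning acetyl into propylcarbonyl. Among the compounds with values here, no measured pair shows this change, so compound 3 at 71800 nM is the only anchor. In this assay, the expected result is a 1.2-fold lower number from compound 3 to compound 4 (0.08 log units; within the scatter), a step not beyond the scatter. For compound 4 the estimated value is 60000 nM, with an expected range of 25000 nM to 110000 nM.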

Compound 4, half-maximal inhibitory concentration: 34500 nM
Estimate against measurement, compound 4: 1.7-fold (0.24 log units) above; the measured number falls inside the stated range.
By their numbers in this assay, from the lowest: compound 2; then compound 4; then compounds 3 and 1 (each within the scatter of the next).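

In this assay, within the data shown here, the change from acetyl to propylcarbonyl gives a 2.1-fold lower number from compound 3 to compound 4 (0.32 log units; beyond the scatter) and is the first step here that alters a single place. It shows that this saturated chain carbon bound to a carbonyl carbon can carry ethyl in place of hydrogen with a modest gain in antiproliferative activity rather than a loss. No measurement shown here accounts for that gain.

A single step cannot show whether a longer chain, such as pentyl, would give a lower or higher number. On these data alone, the effect of an amine or a carboxylic acid at the end of this chain also remains open.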